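The source may report more compounds than this note shows. Statements on the series, on what has been measured and on what is new or still open speak of the compounds shown alone.

In a functional assay on the whole organism with Mus musculus as the target; a lower number here means that less compound is needed, a higher number that more compound is needed for the effect:
- Compound 1 `Cc1c(N)c(C)c2c(c1CN(C)C)OC(C)(C)C2`: > 50 mg/kg, a limit
- Compound 2 `Cc1c(N)c(C)c2c(c1CN1CCCCC1)OC(C)(C)C2`: > 50 mg/kg, a limit

Compound 2 gives > 50 mg/kg, which is a limit and not a number. Compound 3 `CC(C)=Cc1c(C)c(N)c(C)c2c1OC(C)(C)C2` carries 2-methylprop-1-en-1-yl in place of (piperidin-1-yl)methyl on an aromatic carbon. Among the measured compounds shown here, only one measured step bears on this change, a step that the two limits leave unreadable from compound 1 to compound 2, and it gives no size. The evidence amounts to the limit of > 50 mg/kg in this assay, at which 2 of the 2 values shown sit. No size or direction can therefore be drawn from it for this assay, and compound 3 is expected to lie near that limit. The expected step is a number no higher from compound 2 to compound 3 (the limit leaves the size open). For compound 3 the estimate is 50 mg/kg, with an expected range from 15 mg/kg to 150 mg/kg.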

Compound 3, dose for 50% inhibition: 21.9 mg/kg
Estimate against measurement, compound 3: 2.3-fold (0.36 log units) above; the measured number falls inside the stated range.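

In this assay, among the compounds shown here, compound 3 gives the first number at this position rather than a limit, showing that a group without nitrogen here can bring the dose within reach. Replacing (piperidin-1-yl)methyl with 2-methylprop-1-en-1-yl gives an at least 2.2-fold lower number from compound 2 to compound 3 (0.35 log units; beyond the scatter), and replacing (dimethylamino)methyl with it gives an at least 2.2-fold lower number from compound 1 to compound 3 (0.35 log units; beyond the scatter). The step between the two amine-bearing compounds still cannot be read.

The compounds shown do not separate the loss of the amine from the presence of the double bond. As far as these compounds go, a saturated 2-methylpropyl chain at this position would bear on that question, and how far the number could fall also remains open.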